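Dichlorophenyl replaces chloronitrophenyl in a dienone series

The compounds below may be only part of what the source reports. "The series", "measured", "known", "first", "only" and "open" are said of these compounds alone.

The measured compounds are:
compound 1 `O=C(/C=C/c1ccc(Oc2ncnc3ccc(Cl)cc23)cc1)/C=C/c1c(Cl)cccc1Cl` with 9300 nM,
compound 2 `O=C(/C=C/c1ccc(Cl)c([N+](=O)[O-])c1)/C=C/c1ccccc1Oc1ncnc2ccc(Cl)cc12` with 9760 nM,
compound 3 `O=C(/C=C/c1cc([N+](=O)[O-])ccc1Cl)/C=C/c1ccccc1Oc1ncnc2ccc(Cl)cc12` with 2510 nM.

In a functional assay on PC-3 cells (Homo sapiens) for inhibition, read by MTT assay, with a stated time of 72 h (a higher number here means a weaker inhibitor, a lower number a stronger inhibitor), compound 3 stands lowest of the three, its nearest neighbour being compound 1 and the step of a 3.9-fold lower number from compound 2 to compound 3 (0.59 log units; beyond the scatter) separating it from compound 2. Compound 4 `O=C(/C=C/c1ccccc1Oc1ncnc2ccc(Cl)cc12)/C=C/c1cccc(Cl)c1Cl` differs from compound 3 by 2,3-dichlorophenyl in place of 2-chloro-5-nitrophenyl on a double-bonded chain carbon bound to a double-bonded chain carbon. For the measured compounds named here, no measured step covers this exchange; the step from compound 2 to compound 3 only moved the nitro group, and compound 1, which also carries a dichlorophenyl, differs from compound 4 in a second place as well. Compound 4 is therefore expected to give a modestly higher number, a 2.4-fold higher number from compound 3 to compound 4 (0.38 log units; beyond the scatter), with an estimate of 6000 nM and a range of 2000 nM to 18000 nM.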

Compound 4, half-maximal inhibitory concentration: 8350 nM
The estimate for compound 4 lay 1.4-fold (0.14 log units) below the measured number; low and high end bracket the measured number.
By their numbers in this assay, from the lowest: compound 3; then compounds 4, 1 and 2 (each within the scatter of the next).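

At this place on the chain, the 2,3-dichlorophenyl group does not hold the level of the 2-chloro-5-nitrophenyl group in this assay, with a 3.3-fold higher number from compound 3 to compound 4 (0.52 log units; beyond the scatter) on this exchange. Set against the 4-chloro-3-nitrophenyl group, the same group gives a 1.2-fold lower number from compound 2 to compound 4 (0.07 log units; within the scatter) and so cannot be told apart from it, which leaves the 2-chloro-5-nitrophenyl group alone among these three. No measured evidence accounts for this difference. Still open, going by these compounds, is whether a phenyl carrying only a nitro group, or an amine or a carboxylic acid on that ring, would match compound 3 or fall with compound 2 and compound 4.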